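From an Ester Chain End to a Ring-Bearing Group

The source may hold more compounds than are shown below. What is called first, only, known or untested is meant among the compounds shown, and "the series" means these compounds.

In a functional assay on CCRF-CEM cells (Homo sapiens) (on this read-out higher numbers stand for lower toxicity in this test and lower numbers for higher toxicity in this test), three compounds share one core and differ in the chain on an aromatic nitrogen. Compound 1 `Cc1cn([C@@H]2O[C@H](CO[Si](C)(C)C(C)(C)C)[C@@]3(OS(=O)(=O)C=C3N)[C@H]2O[Si](C)(C)C(C)(C)C)c(=O)n(Cc2ccccc2)c1=O` gives 53000 nM. Among the compounds with values here, compound 3 `COC(=O)CCCCn1c(=O)c(C)cn([C@@H]2O[C@H](CO[Si](C)(C)C(C)(C)C)[C@@]3(OS(=O)(=O)C=C3N)[C@H]2O[Si](C)(C)C(C)(C)C)c1=O` gives 125000 nM, the highest actual number so far. Compound 2 `CNC(=O)Cn1c(=O)c(C)cn([C@@H]2O[C@H](CO[Si](C)(C)C(C)(C)C)[C@@]3(OS(=O)(=O)C=C3N)[C@H]2O[Si](C)(C)C(C)(C)C)c1=O` reads >= 250000 nM, which is a limit of the assay and not a number.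

Compound 4 `Cc1cn([C@@H]2O[C@H](CO[Si](C)(C)C(C)(C)C)[C@@]3(OS(=O)(=O)C=C3N)[C@H]2O[Si](C)(C)C(C)(C)C)c(=O)n(CCCN2C(=O)c3ccccc3C2=O)c1=O` is still unmeasured, and its difference from compound 3 is this: a group of 11 heavy atoms (8 carbon, 1 nitrogen, 2 oxygen; one five-membered non-aromatic ring with 1 hetero atom, one six-membered aromatic ring of carbon only) in place of a group of 5 heavy atoms (3 carbon, 2 oxygen; no ring), on a saturated chain carbon, three bonds along the chain from an aromatic nitrogen. Within the data shown here, two measured steps bear on the change, and both leave the phenyl group of compound 1: a 2.4-fold higher number from compound 1 to compound 3 (0.37 log units; beyond the scatter) and an at least 4.7-fold higher number from compound 1 to compound 2 (0.67 log units; beyond the scatter). Of these three compounds, only compound 1 carries a six-membered aromatic ring of carbon only, and it has the lowest number. Three compounds are a thin basis, but compound 4 regains such a ring, so in this assay a modest move towards compound 1 at 53000 nM is expected. The expected step is a 1.6-fold lower number from compound 3 to compound 4 (0.19 log units; within the scatter), which may not clear the usual scatter. For compound 4 the estimated value is 80000 nM, with an expected range from 30000 nM to 190000 nM.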

Compound 4, half-maximal cytotoxic concentration: > 250000 nM
Compound 4 was reported as a limit; the forecaster's own chance of this, stated with the estimate: 15%; middle value at least 3.1-fold (0.49 log units) away from the limit.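

In this assay compound 4 reads > 250000 nM, which is a limit of the assay and not a number. The change at this place on the chain gives an at least 2.0-fold higher number from compound 3 to compound 4 (0.30 log units; that floor lies within the scatter), so the larger group with its two rings does not bring the number down, though the floor of this step does not clear the scatter. Within the data shown here, compound 4 regains a six-membered aromatic ring of carbon only, yet it goes against the pattern of the earlier compounds, so carrying such a ring is not enough to give the low number of compound 1, which reads 53000 nM.

Compound 2 also reads as a limit, so no order between it and compound 4 can be read. Still open, going by these compounds, is whether a longer chain ending in phenyl, or a chain ending in an amine or a carboxylic acid, would give a number that can be read.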